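This account rests on a few compounds, and the source may have more. Where it says the series, first, only, none or still open, it means among the compounds named here.

Working notes on the series. All three measured compounds share one core and differ only in the aryl group on the double-bonded chain carbon. Compound 1 `O=C(COc1ccc(C(=O)/C=C/c2ccccc2Cl)cc1)N[C@H]1CCOC1=O` carries a 2-chlorophenyl there and in a functional assay on MCF7 cells (Homo sapiens) for antiproliferative activity, read by MTT assay, with a stated time of 72 h (a higher number here means a weaker inhibitor, a lower number a stronger inhibitor), compound 1 gives 17400 nM. Compound 2 `CC(C)(C)c1ccc(/C=C/C(=O)c2ccc(OCC(=O)N[C@H]3CCOC3=O)cc2)cc1` carries a 4-(tert-butyl)phenyl and in this assay compound 2 gives 16400 nM. Compound 3 `O=C(COc1ccc(C(=O)/C=C/c2cccc(Br)c2)cc1)N[C@H]1CCOC1=O` carries a 3-bromophenyl and in this assay compound 3 gives 28300 nM. On these numbers compound 3 has the highest of the three values, yet its gaps to both other compounds stay within the scatter: a 1.6-fold higher number from compound 1 to compound 3 (0.21 log units; within the scatter) and a 1.7-fold higher number from compound 2 to compound 3 (0.24 log units; within the scatter). Likewise a 1.1-fold lower number from compound 1 to compound 2 (0.03 log units; within the scatter). Nothing in the measured set separates one aryl group from another.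

Compound 4 `O=C(COc1ccc(C(=O)/C=C/c2ccccc2)cc1)N[C@H]1CCOC1=O` is the unmeasured member. Its change from compound 3 is hydrogen in place of bromo on an aromatic carbon, that is, the bromo is removed and the ring is left bare. Within the data shown here, no measured step removes a substituent outright; the two steps that reach compound 3 swap one substituted ring for another and both fall within the scatter. On that basis no step beyond the scatter is expected for a 1.3-fold lower number from compound 3 to compound 4 (0.11 log units; within the scatter), and compound 4 is estimated at 22000 nM in this assay, with a range from 9000 nM to 55000 nM.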

Compound 4, half-maximal inhibitory concentration: > 64000 nM
Compound 4 ended at the assay's limit; the forecaster's own chance of this, stated with the estimate: 10%; middle value at least 2.9-fold (0.46 log units) away from the limit.
By their numbers in this assay, from the lowest: compounds 2, 1 and 3 (each within the scatter of the next). At a limit, above all of these: compound 4.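

In this assay compound 4 stands at a limit of the assay and not at a number: the limit of > 64000 nM in this assay, at which 1 of the 4 values shown sits. Taking away the substituent is the first change on this aromatic ring to go beyond the scatter, with an at least 2.2-fold higher number from compound 3 to compound 4 (0.35 log units; beyond the scatter), an at least 3.9-fold higher number from compound 2 to compound 4 (0.59 log units; beyond the scatter) and an at least 3.6-fold higher number from compound 1 to compound 4 (0.56 log units; beyond the scatter). The 2-chlorophenyl, 4-(tert-butyl)phenyl and 3-bromophenyl compounds cannot be told apart from one another, yet each stands apart from the bare phenyl of compound 4, so among these four compounds the presence of a substituent on this ring separates the values, while the choice among these three substituents does not.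

From the compounds shown here alone, no single group appears here at more than one place on the ring, so the effect of the group and the effect of its place remain unseparated, and the true size of all three steps stays open with compound 4 at a limit. Also open, going by these compounds, is whether a ring carrying an amine, a carboxylic acid or a methoxy group would fall with the three substituted compounds or with compound 4.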